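The source may hold more compounds than are shown below. What is called first, only, known or untested is meant among the compounds shown, and "the series" means these compounds.

Of the compounds shown here, three that share one core have been tested in a functional assay on HeLa cells (Homo sapiens) for inhibition; on this read-out lower numbers stand for stronger inhibition and higher numbers for weaker inhibition. Compound 1 `Oc1cccc(-c2cc(-c3ccc(F)cc3)cc(-c3ccccc3O)n2)c1` gives only a limit in this assay, > 50000 nM. Compound 2 `Oc1ccc(-c2cc(-c3ccc(F)cc3)cc(-c3ccccc3O)n2)cc1` likewise gives only a limit in this assay, > 50000 nM. Within the data shown here, compound 3 `Oc1ccc(-c2cc(-c3ccccc3F)cc(-c3cccc(O)c3)n2)cc1` is the one compound with a number in this assay, 14300 nM. The change from compound 1 to compound 2 is 4-hydroxyphenyl in place of 3-hydroxyphenyl on an aromatic carbon; its step, a step that the two limits leave unreadable from compound 1 to compound 2, cannot be read because both ends sit at the limit of > 50000 nM in this assay, at which 2 of the 3 values shown sit.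

Compound 4 `Oc1ccc(-c2cc(-c3ccccc3F)cc(-c3ccc(O)cc3)n2)cc1` has not yet been measured. It differs from compound 3 by 4-hydroxyphenyl in place of 3-hydroxyphenyl on an aromatic carbon. The difference between the core of compound 1 and the core of compound 3 is not broken down here. The surroundings of the change also differ: in the first pair the place is meta to a 2-hydroxyphenyl group and meta to a 4-fluorophenyl group, in the second pair meta to a 2-fluorophenyl group and meta to a 4-hydroxyphenyl group, so this is the same kind of change rather than the same change.

The earlier step being unreadable, the expectation for compound 4 rests mainly on compound 3 with 14300 nM, and the expected step of a 1.4-fold higher number from compound 3 to compound 4 (0.15 log units; within the scatter) is small. Compound 4 is therefore expected to give about 20000 nM in this assay, most likely between 7000 nM and 50000 nM.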

Compound 4, half-maximal inhibitory concentration: > 50000 nM
Compound 4 ended at the assay's limit (the forecaster's own chance of this, stated with the estimate: 35%); at least 2.5-fold (0.39 log units) between middle value and limit.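

In this assay, replacing 3-hydroxyphenyl with 4-hydroxyphenyl gives an at least 3.4-fold higher number from compound 3 to compound 4 (0.54 log units; beyond the scatter), so on the core of compound 3 this change weakens inhibition by more than the usual scatter. As far as these compounds go, compound 4 gives only a limit, > 50000 nM, so the printed step is a minimum and its full size stays unknown. This is the only readable case of the change, and whether it has the same effect on the core of compound 1 remains unknown, because the step between compound 1 and compound 2 cannot be read: the limit of > 50000 nM in this assay, at which 3 of the 4 values shown sit.

The two cores differ in more than one place, and the compounds shown do not reveal which difference allows compound 3 to give a number while compound 1 and compound 2 do not. From the compounds shown here alone, it also remains open how inhibition would respond if an amine or a carboxylic acid took the place of the hydroxyl group on this ring.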